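The source may report more compounds than this note shows. Statements on the series, on what has been measured and on what is new or still open speak of the compounds shown alone.

Working notes on the series.

Compound 1 `COc1ccc(C2=NN(C3=NC(=O)/C(=C4\C(=O)Nc5ccccc54)S3)C(c3ccc(Cl)cc3)C2)cc1` and compound 2 `COc1ccc(C2=NN(C3=NC(=O)/C(=C4\C(=O)Nc5ccc(Br)cc54)S3)C(c3ccc(Cl)cc3)C2)cc1` are built on one core; compound 3 `CN(C)c1ccc(C2CC(c3ccccc3)=NN2C2=NC(=O)/C(=C3\C(=O)Nc4ccccc43)S2)cc1` and compound 4 `CN(C)c1ccc(C2CC(c3ccccc3)=NN2C2=NC(=O)/C(=C3\C(=O)Nc4ccc(Br)cc43)S2)cc1` are built on another. The difference between the two cores is not broken down here. All four belong in a functional assay on cells (Melanoma cell, Homo sapiens) for cytotoxicity, read by sulforhodamine B assay, with a stated time of 48 h; a higher number here means a weaker inhibitor of growth, a lower number a stronger inhibitor of growth.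

In this assay compound 1 gives 100000 nM. Compound 2 carries the change bromo in place of hydrogen on an aromatic carbon and in this assay compound 2 gives 340 nM. Within the data shown here, that single pair yields a 290-fold lower number from compound 1 to compound 2 (2.47 log units; beyond the scatter), the only measured precedent for the bromo substitution in this set.

On the second core, compound 3 in this assay gives 29400 nM. Its value stands between those of compound 1 and compound 2, closer to compound 1.

Compound 4 has not yet been measured. It differs from compound 3 by bromo in place of hydrogen on an aromatic carbon, and the place is described in the same words as for the change from compound 1 to compound 2, so it is the same change, now on the second core. Going by these compounds, whether the second core responds as the first did is unknown; with one precedent only, a step of the same sign but somewhat smaller size is expected, so the expected step is a 98-fold lower number from compound 3 to compound 4 (1.99 log units; beyond the scatter), held short of a 290-fold lower number from compound 1 to compound 2 (2.47 log units; beyond the scatter) to allow for the change of core. Compound 4 is therefore expected near 300 nM, within a range from 60 nM to 3000 nM.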

Compound 4, concentration for total growth inhibition: 460 nM
Compound 4: the middle estimate sits 1.5-fold (0.19 log units) below what was measured; measured number inside the range.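

On the second core, bromo in place of hydrogen on an aromatic carbon again strengthens growth inhibition in this assay, with a 64-fold lower number from compound 3 to compound 4 (1.81 log units; beyond the scatter), so the direction of the change carries over from the core of compound 1 to the core of compound 3. The size does not carry over unchanged, as the step on the second core is the smaller of the two: the same change on two cores in this assay, a 290-fold lower number (2.47 log units; beyond the scatter) from compound 1 to compound 2 and a 64-fold lower number (1.81 log units; beyond the scatter) from compound 3 to compound 4, 4.6-fold (0.66 log units) apart, beyond the scatter of two such steps

This shows that the sign of the step is shared by these two matched pairs and that a large step appears on both cores, but it does not show a rule for other cores in the series, and the pairs do not reveal which of the differences between the two cores goes with the gap in step size.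

The compounds shown carry only hydrogen or bromo on this aromatic carbon, so it remains open whether chloro, a methoxy group, an amine or a carboxylic acid in the same place would give a step of similar direction and size on either core. Among these compounds, also open is how the bromo step behaves on a core that differs from these two in only one of its aryl groups, which would separate the contributions of the two aryl changes.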